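Thiophen-3-yl to 3-methyl-1,2-oxazol-5-yl on the shared core

The source may report more compounds than this note shows. Statements on the series, on what has been measured and on what is new or still open speak of the compounds shown alone.

In a functional assay on SNB-19 cells (Homo sapiens) for inhibition, read by MTT assay, with a stated time of 7 days (a higher number here means a weaker inhibitor of growth, a lower number a stronger inhibitor of growth), compound 1 `C[Si](C)(C)Cn1nnc2c(C(N)=O)ncn2c1=O` gives 28400 nM. Compound 2 `C[Si](C)(C)CCOCn1nnc2c(C(N)=O)ncn2c1=O` gives 29900 nM in this assay, and a 1.1-fold higher number from compound 1 to compound 2 (0.02 log units; within the scatter) stays within the scatter. Compound 3 `NC(=O)c1ncn2c(=O)n(Cc3ccsc3)nnc12` gives > 50000 nM, which is a limit of the assay and not a number. This reading is the limit of > 50000 nM in this assay, at which 1 of the 3 values shown sits, so compound 3 has no exact value in the series.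

Compound 4 `Cc1cc(Cn2nnc3c(C(N)=O)ncn3c2=O)on1` has not yet been measured. The change is 3-methyl-1,2-oxazol-5-yl in place of thiophen-3-yl on a saturated chain carbon bound to an aromatic nitrogen.

Three measured steps act at this same place. Two of them end at the limit: an at least 1.7-fold higher number from compound 1 to compound 3 (0.24 log units; that floor lies within the scatter) and an at least 1.6-fold higher number from compound 2 to compound 3 (0.22 log units; that floor lies within the scatter). Both are floors that lie within the scatter. The third, a 1.1-fold higher number from compound 1 to compound 2 (0.02 log units; within the scatter), is also within the scatter. None of the three involves 3-methyl-1,2-oxazol-5-yl, and none shows a substituent at this place moving the number beyond the scatter. No step beyond the scatter is therefore expected in this assay. The expected change is a number no higher from compound 3 to compound 4 (the limit leaves the size open). The estimated value for compound 4 is 50000 nM, with an expected range of 25000 nM to 100000 nM.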

Compound 4, concentration for 50% growth inhibition: > 50000 nM
Compound 4 was reported as a limit; the forecaster's own chance of this, stated with the estimate: 60%; the middle value lies on the limit itself.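

In this assay the reading for compound 4 is a limit of the assay and not a number, so a second group with a five-membered aromatic ring ends on the limit at this saturated chain carbon bound to an aromatic nitrogen: the limit of > 50000 nM in this assay, at which 2 of the 4 values shown sit.

Compound 3 and compound 4 both stand as limits, so the step between them cannot be read, and swapping thiophen-3-yl for 3-methyl-1,2-oxazol-5-yl yields no size of effect. Against the groups with no ring, the series now shows an at least 1.6-fold higher number from compound 2 to compound 4 (0.22 log units; that floor lies within the scatter) and an at least 1.7-fold higher number from compound 1 to compound 4 (0.24 log units; that floor lies within the scatter), and these floors, like those to compound 3, do not separate the ring-bearing groups from the silicon-bearing chains.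

As far as these compounds go, whether any group at this place moves the number beyond the scatter stays open, as does any ranking of the two ring-bearing groups. A plain phenyl ring, a longer alkyl chain or a chain ending in an amine at this place would be the next comparisons, provided their values fall inside the readable range.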